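This account rests on a few compounds, and the source may have more. Where it says the series, first, only, none or still open, it means among the compounds named here.

Compound 1 `CC(/C=N/Nc1ccc([N+](=O)[O-])cc1)=N\NC(=O)c1ccccc1` — in an ADME assay on J774 cells (Mus musculus, strain BALB/c) for cytotoxicity, read by resazurin assay, with a stated time of 72 h (a higher number here means that more compound is tolerated, a lower number that less compound is tolerated), compound 1 gives > 100000 nM, which is a limit of the assay rather than a number.
Compound 2 `CC(/C=N/Nc1ccc([N+](=O)[O-])cc1)=N\NC(=O)c1ccccc1Nc1ccccc1` — compound 2 gives > 100000 nM, again a limit.
Compound 3 `CC(/C=N/Nc1ccc([N+](=O)[O-])cc1)=N\NC(=O)c1ccccc1C` — compound 3 gives > 100000 nM, also a limit.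

Compound 2 thus stands at the limit of > 100000 nM in this assay, at which 3 of the 3 values shown sit, with no number of its own. Compound 4 `CC(/C=N/Nc1ccc([N+](=O)[O-])cc1)=N\NC(=O)c1ccccc1N` differs from compound 2 by hydrogen in place of phenyl on a nitrogen on an aromatic ring. The measured steps that touch the same carbon, a step that the two limits leave unreadable from compound 1 to compound 2 and a step that the two limits leave unreadable from compound 2 to compound 3, are both unreadable between the limits, so neither a direction nor a size beyond the scatter can be drawn from them. The expected step is therefore a number no higher from compound 2 to compound 4 (the limit leaves the size open). Compound 4 is expected at 100000 nM, with a range from 30000 nM to 300000 nM, and most likely reported once more only as a limit.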

Compound 4, half-maximal cytotoxic concentration: 29800 nM
Compound 4: middle estimate off by 3.4-fold (0.53 log units), on the high side, and the stated range ends above it.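

Amino is the only change shown at this aromatic carbon that gives a readable step in this assay, with an at least 3.3-fold lower number from compound 1 to compound 4 (0.52 log units; beyond the scatter). Set against methyl at the same carbon the result is an at least 3.3-fold lower number from compound 3 to compound 4 (0.52 log units; beyond the scatter), and with the phenyl taken off the nitrogen it is an at least 3.3-fold lower number from compound 2 to compound 4 (0.52 log units; beyond the scatter). All three sizes are lower bounds, and the other compounds stay at one limit: the limit of > 100000 nM in this assay, at which 3 of the 4 values shown sit.

The compounds shown leave open whether a methylamino group, an acetamido group or a carboxylic acid on this aromatic carbon would also lower the number. On these data alone, the full size of the three steps also stays open.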